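The source may hold more compounds than are shown below. What is called first, only, known or untested is meant among the compounds shown, and "the series" means these compounds.

Measured so far:
compound 1, `CNC(=O)c1cc(Oc2ccc(NC(=O)c3cc(-c4ccc(F)cc4)ncn3)cc2F)ccn1` — > 100000 nM
compound 2, `CNC(=O)c1cc(Oc2ccc(NC(=O)c3cc(-c4ccc(Cl)cc4)ncn3)cc2)ccn1` — > 100000 nM

Of the compounds shown here, two have been tested in a functional assay on A549 cells (Homo sapiens) for cytotoxicity, read by MTT assay, with a stated time of 72 h (a higher number here means a weaker inhibitor, a lower number a stronger inhibitor), and neither gave a number. Compound 2, `CNC(=O)c1cc(Oc2ccc(NC(=O)c3cc(-c4ccc(Cl)cc4)ncn3)cc2)ccn1`, reached only the limit of the assay, > 100000 nM, which is a limit and not a measured value. Compound 1, `CNC(=O)c1cc(Oc2ccc(NC(=O)c3cc(-c4ccc(F)cc4)ncn3)cc2F)ccn1`, likewise stopped at the limit, > 100000 nM. Both values therefore sit at the same point: the limit of > 100000 nM in this assay, at which 2 of the 2 values shown sit. Among the compounds with values here, there is no step between measured compounds here, and compound 2 stands at the limit with no number to rank it against.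

The next compound, compound 3, `CNC(=O)c1cc(Oc2ccc(NC(=O)c3cc(-c4ccc(F)cc4)ncn3)cc2)ccn1`, differs from compound 2 in one place: fluoro in place of chloro on an aromatic carbon. Within the data shown here, no measured step shows what this change does in this assay, and no effect of the fluoro or the chloro on the readout has been measured.

Given that compound 2 gives > 100000 nM, compound 3 is expected to behave the same way, with no step beyond the scatter: a number no higher from compound 2 to compound 3 (the limit leaves the size open). For compound 3 the estimate in this assay is 100000 nM, ranging from 40000 nM to 300000 nM, and most likely the assay will again report only a limit.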

Compound 3, half-maximal inhibitory concentration: > 100000 nM
Compound 3: no number, only a limit; the forecaster's own chance of this, stated with the estimate: 85%; the middle value sits exactly at the limit.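

Compound 3 also stops at a limit of the assay, so the steps from compound 2 to compound 3 and from compound 1 to compound 3 cannot be read: the limit of > 100000 nM in this assay, at which 3 of the 3 values shown sit. The compounds shown leave open whether any change to the shared core would give a real number in this assay and what fluoro in place of chloro does there.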